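The source may hold more compounds than are shown below. What is called first, only, known or untested is meant among the compounds shown, and "the series" means these compounds.

Of the compounds shown here, three sharing one core have been measured in a functional assay on PC-12 cells (Rattus norvegicus) for cytotoxicity, read by MTT assay, with stated times of 2 h and 24 h, tested at 10 uM; a lower number here means a weaker effect, a higher number a stronger effect of the compound at the concentration tested. Compound 1 `Cc1ccc(-n2nc(-c3ccc(C(F)(F)F)cc3O)nc2-c2ccccc2O)cc1` gives 102%. Compound 2 `Oc1cc(C(F)(F)F)ccc1-c1nc(-c2ccccc2O)n(-c2ccc(Cl)cc2)n1` gives 96.1%. Compound 3 `Oc1cc(C(F)(F)F)ccc1-c1nc(-c2ccccc2O)n(-c2ccc(Br)cc2)n1` gives 100%. All three values lie within the scatter of one another: the step of a number 2 percentage points lower from compound 1 to compound 3 (within the scatter) and the step of a number 3.9 percentage points higher from compound 2 to compound 3 (within the scatter) are both small, as is the step of a number 5.9 percentage points lower from compound 1 to compound 2 (within the scatter), so compound 3 cannot be told apart from the other two on these numbers.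

Compound 4 `Oc1cc(C(F)(F)F)ccc1-c1nc(-c2ccccc2O)n(-c2ccc(OC(F)(F)F)cc2)n1` differs from compound 3 in one place: trifluoromethoxy in place of bromo on an aromatic carbon. The two measured steps that bear on this change are the ones that alter the same aromatic position, a number 2 percentage points lower from compound 1 to compound 3 (within the scatter) and a number 3.9 percentage points higher from compound 2 to compound 3 (within the scatter), and neither moved the read-out beyond the scatter. On that basis no step beyond the scatter is expected here either, and the step of a number 1 percentage points lower from compound 3 to compound 4 (within the scatter) is estimated to be small. Compound 4 is therefore expected to give about 99% in this assay, most likely between 88% and 108%.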

Compound 4, a percentage reported as activity, at one concentration (the size of the read-out at that concentration, not a potency): 92.5%
Compound 4: middle estimate off by 6.5 percentage points, on the high side; low and high end bracket the measured number.
By their numbers in this assay, from the lowest: compounds 4, 2, 3 and 1 (each within the scatter of the next).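

Trifluoromethoxy puts five heavy atoms and a hydrogen-bond acceptor where bromo has one heavy atom and no acceptor, yet in this assay the result is a number 7.5 percentage points lower from compound 3 to compound 4 (within the scatter). Set against the other two groups, the change gives a number 3.6 percentage points lower from compound 2 to compound 4 (within the scatter) and a number 9.5 percentage points lower from compound 1 to compound 4 (within the scatter), so methyl, chloro, bromo and trifluoromethoxy on this aromatic carbon cannot be told apart on these numbers, even though the newest group is clearly larger by atom count. No measurement of any property of these groups is available to connect them with the read-out.

On these data alone, whether an amine, a carboxylic acid or a longer chain at this position would move the read-out beyond the scatter remains open. So does whether changes elsewhere on the shared core, such as replacing the trifluoromethyl group, would do so.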